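Swapping an ester for an amide on a glycoside

This account rests on a few compounds, and the source may have more. Where it says the series, first, only, none or still open, it means among the compounds named here.

Of the compounds shown here, two of this shared core have been tested in a functional assay on SK-BR-3 cells (Homo sapiens) for antiproliferative activity, read by MTT assay, with a stated time of 72 h; a higher number here means a weaker inhibitor, a lower number a stronger inhibitor. Compound 1 `C/C=C1/[C@H](O[C@@H]2O[C@H](COC(C)=O)[C@@H](OC(C)=O)[C@H](OC(C)=O)[C@H]2OC(C)=O)OC=C(C(=O)OC)[C@H]1CC(=O)OCCC` gives 6600 nM. For compound 2 `C/C=C1/[C@H](O[C@@H]2O[C@H](CO)[C@@H](O)[C@H](O)[C@H]2O)OC=C(C(=O)OC)[C@H]1CC(=O)OCCc1ccc(O)cc1` the result is only a limit, > 20000 nM, which is the limit of > 20000 nM in this assay, at which 1 of the 2 values shown sits. Compound 3 `C/C=C1/[C@H](O[C@@H]2O[C@H](CO)[C@@H](O)[C@H](O)[C@H]2O)OC=C(C(=O)OC)[C@H]1CC(=O)NCCC` is compound 2 with a single change: propylamino in place of 2-(4-hydroxyphenyl)ethoxy on a carbonyl carbon. Among the measured compounds shown here, no measured pair of compounds shares this change, so its effect on this assay is unknown, and no step beyond the usual scatter is expected in either direction. Compound 3 is therefore estimated at 25000 nM, within a range of 8000 nM to 80000 nM. The expected step is a step that the limit leaves unreadable from compound 2 to compound 3, essentially none.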

Compound 3, half-maximal inhibitory concentration: > 20000 nM
Compound 3: a limit, no number (the forecaster's own chance of this, stated with the estimate: 60%); the middle value is on the limit's open side.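

No step can be read from compound 2 to compound 3, because both results are limits rather than numbers: the limit of > 20000 nM in this assay, at which 2 of the 3 values shown sit.

Going by these compounds, whether propylamino in place of 2-(4-hydroxyphenyl)ethoxy on a carbonyl carbon changes activity in this assay remains open.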